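The source may hold more compounds than are shown below. What is called first, only, known or untested is meant among the compounds shown, and "the series" means these compounds.

Working notes on the series. In a functional assay for agonist activity at G protein-coupled receptor 88 (Homo sapiens), read by HTRF and cAMP accumulation (a higher number here means that more compound is needed for the effect, a lower number that less compound is needed), compound 1 `CC(C)C[C@H](N)CN(C(=O)[C@@H]1C[C@H]1c1ccccc1)c1ccc(-c2ccccc2)cc1` gives 880 nM. Compound 2 `CC(C)C[C@@H](N)CN(C(=O)[C@@H]1C[C@H]1c1ccccc1)c1ccc(-c2ccccc2)cc1` gives 1.8 nM; a 490-fold lower number from compound 1 to compound 2 (2.69 log units; beyond the scatter), and the size of that step rests on (the fact that compounds 1 and 2 differ only in the configuration as drawn). Compound 3 `CC[C@H](C)[C@@H](CN(C(=O)[C@@H]1C[C@H]1c1ccccc1)c1ccc(-c2ccccc2)cc1)NC(C)=O` gives 5.8 nM, the second highest of the three numbers; a 3.2-fold higher number from compound 2 to compound 3 (0.51 log units; beyond the scatter), while a 150-fold lower number from compound 1 to compound 3 (2.18 log units; beyond the scatter).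

Compound 4 `CC[C@@H](C)[C@H](N)CN(C(=O)[C@@H]1C[C@H]1c1ccccc1)c1ccc(-c2ccccc2)cc1` is next, not yet measured. The change from compound 3 is 1-amino-2-methylbutyl in place of 1-acetamido-2-methylbutyl on a saturated chain carbon bound to an amide-type nitrogen, so the free amine of compound 2 is restored while the 2-methylbutyl chain of compound 3 is kept. The step from compound 2 to compound 3 bears on it most directly, so a modest lowering is expected, with a 2.3-fold lower number from compound 3 to compound 4 (0.37 log units; beyond the scatter). Compound 4 is estimated at 2.5 nM, between 0.8 nM and 8 nM.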

Compound 4, half-maximal effective concentration: 1.4 nM
The estimate for compound 4 lay 1.8-fold (0.25 log units) above the measured number; the measured number falls inside the stated range.
By their numbers in this assay, from the lowest: compounds 4 and 2 (each within the scatter of the next); then compound 3; then compound 1.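

Removing the acetyl group while keeping the 2-methylbutyl chain gives a 4.1-fold lower number from compound 3 to compound 4 (0.62 log units; beyond the scatter), so with this chain the free amine is favoured over the acetamide. With the amine in place, the change of chain gives a 1.3-fold lower number from compound 2 to compound 4 (0.11 log units; within the scatter), so 1-amino-2-methylbutyl and 1-amino-3-methylbutyl are not separated in this assay. The series also shows a 630-fold lower number from compound 1 to compound 4 (2.80 log units; beyond the scatter), which joins the large step to compound 2 and points to configuration rather than to the chain: the fact that compounds 1 and 2 differ only in the configuration as drawn

Still open, on these data alone, is whether a dimethylamine or a carboxylic acid would be accepted in place of the amine. Also open, as far as these compounds go, is whether a longer chain than 2-methylbutyl would hold the number.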